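Amide-bearing chain in place of a carboxy group on a fused core

The source may report more compounds than this note shows. Statements on the series, on what has been measured and on what is new or still open speak of the compounds shown alone.

Measured compounds:
compound 1 `O=c1n(Cc2nc3ccc(F)cn3c2CCCCO)c2cnccc2n1C1CC1`, in an ADME assay on HEp-2 cells (Homo sapiens) for cytotoxicity, read by CCK-8 assay, with a stated time of 6 days (on this read-out lower numbers stand for higher toxicity in this test and higher numbers for lower toxicity in this test), compound 1 gives > 100000 nM, a limit of the test.
compound 2 `O=c1n(Cc2nc3cc(F)ccn3c2CCCCO)c2cnccc2n1C1CC1`, in this assay compound 2 gives > 100000 nM, again a limit.
compound 3 `O=C(O)c1c(Cn2c(=O)n(C3CC3)c3ccncc32)nc2cc(Cl)ccn12`, in this assay compound 3 gives > 100000 nM, likewise a limit.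

Compound 3 therefore stands where every other value in this set stands: on the limit rather than on a number, as the limit of > 100000 nM in this assay, at which 3 of the 3 values shown sit, shows. Among the compounds with values here, no compound here separates from another, so nothing can be said about order among them.

Compound 4 `O=C(CCc1c(Cn2c(=O)n(C3CC3)c3ccncc32)nc2cc(Cl)ccn12)NCCO` is not yet measured. It differs from compound 3 by 2-((2-hydroxyethyl)carbamoyl)ethyl in place of carboxy on an aromatic carbon, in words 2-((2-hydroxyethyl)carbamoyl)ethyl in place of carboxy on an aromatic carbon. Within the data shown here, no measured step exists in this assay for this kind of change, and the shared core of compounds 1, 2 and 3 has given only limits. The account therefore expects no step beyond the scatter for compound 4, and the estimated step from compound 3 to compound 4 is a step that the limit leaves unreadable from compound 3 to compound 4. Compound 4 is estimated at 150000 nM, with a range from 50000 nM to 500000 nM, most likely reported again as a limit.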

Compound 4, half-maximal cytotoxic concentration: > 100000 nM
Compound 4 was reported as a limit; the forecaster's own chance of this, stated with the estimate: 85%; the middle value is on the limit's open side.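

In this assay compound 4 gives > 100000 nM as a limit of the test. Within the data shown here, compound 3 also stands on a limit, so no step from compound 3 to compound 4 can be read. The compounds shown leave open at what concentration, if any, any of them becomes toxic to these cells.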